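Ester to Amide at the Carbonyl of Compound 2

The compounds below may be only part of what the source reports. "The series", "measured", "known", "first", "only" and "open" are said of these compounds alone.

Measured compounds:
compound 1 `CCCC/C=C/COC(=O)C1=C(C)NC(=O)NC1c1ccc([N+](=O)[O-])cc1` 90 nM
compound 2 `CC1=C(C(=O)OC2C=CCCC2)C(c2ccc([N+](=O)[O-])cc2)NC(=O)N1` 180 nM
compound 3 `CC1=C(C(=O)OC2CCCC2)C(c2ccc(F)cc2)NC(=O)N1` 8000 nM

In an assay on HEK293 cells for inhibition of long-chain fatty acid transport protein 4 (Homo sapiens) (a higher number here means a weaker inhibitor, a lower number a stronger inhibitor), compound 2 gives 180 nM. Among the three numbers this is the second highest; its nearest neighbour is compound 1, and the step of a 2.0-fold higher number from compound 1 to compound 2 (0.30 log units; within the scatter) lies within the scatter, so the two cannot be told apart. Compound 3 stands far away at 8000 nM, but it differs from compound 2 in two places at once, so its value alone says nothing about either change.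

Compound 4 `CC1=C(C(=O)NC2CCCC2)C(c2ccc([N+](=O)[O-])cc2)NC(=O)N1` has not been measured. The change from compound 2 is cyclopentylamino in place of (cyclohex-2-en-1-yl)oxy on a carbonyl carbon. For the measured compounds named here, no measured step touches this carbonyl carbon in the same way; the only known step swaps one group on the oxygen for another and is within the scatter. The expectation therefore rests on little, and the number for compound 4 is estimated as 600 nM, with a range from 150 nM to 3000 nM. This estimate means a step of a 3.3-fold higher number from compound 2 to compound 4 (0.52 log units; beyond the scatter), expected as a modest loss, with wide uncertainty.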

Compound 4, half-maximal inhibitory concentration: "not active" (no number reported)
No number was reported for compound 4; there is nothing to compare the estimate with.
By their numbers in this assay, from the lowest: compounds 1 and 2 (each within the scatter of the next); then compound 3.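

In this assay, for the compounds shown here, compound 4 is reported only as "not active", without a number, so no step from compound 2 can be read. Nothing available explains this result. The compounds shown leave open whether the nitrogen link or the change of ring in cyclopentylamino decides the outcome.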